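The source may report more compounds than this note shows. Statements on the series, on what has been measured and on what is new or still open speak of the compounds shown alone.

Compound 1 `CSc1nc(NCCCc2ccccc2)c2ccccc2n1` is a weakly acting member of a small set tested in a functional assay on HT-29 cells (Homo sapiens) for cytotoxicity, read by MTT assay, with a stated time of 72 h; on this read-out higher numbers stand for weaker inhibition of growth and lower numbers for stronger inhibition of growth. In this assay, for the measured compounds named here, compound 1 gives 89600 nM, the only outright number among the values shown. Compound 2 `COc1ccc(CNc2nc(SC)nc3ccccc23)cc1` gives > 100000 nM in this assay, which is a limit of the assay and not a number (the limit of > 100000 nM in this assay, at which 1 of the 2 values shown sits). Compound 3 `CSc1nc(NCCCCCO)c2ccccc2n1` is not yet measured; it differs from compound 1 by 2-hydroxyethyl in place of phenyl on a saturated chain carbon, three bonds along the chain from a nitrogen on an aromatic ring. Going by the values given here, no step between measured compounds is available, and the expected step is a 1.7-fold higher number from compound 1 to compound 3 (0.22 log units; within the scatter), a move beyond the usual scatter toward weaker inhibition of growth. Compound 3 is therefore estimated at 150000 nM, with a range from 50000 nM to 400000 nM.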

Compound 3, concentration for total growth inhibition: > 100000 nM
Compound 3 gave a limit, no number (the forecaster's own chance of this, stated with the estimate: 60%); the middle value does not contradict the limit.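

In this assay, putting 2-hydroxyethyl in place of phenyl on this chain gives an at least 1.1-fold higher number from compound 1 to compound 3 (0.04 log units; that floor lies within the scatter). For the compounds shown here, this is the first view of a change at this position, and it shows that losing the phenyl ring brings no measurable gain in inhibition of growth. Compound 3 gives > 100000 nM, a limit of the assay and not a number, so the true size of the step stays unknown: the limit of > 100000 nM in this assay, at which 2 of the 3 values shown sit.

As far as these compounds go, whether an amine or a carboxylic acid in this place would give a measurable value remains open. So does the effect of a longer chain that keeps the phenyl ring.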